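The compounds below may be only part of what the source reports. "The series", "measured", "known", "first", "only" and "open" are said of these compounds alone.

Compound 1 `O=C1C=COC(/C=C/c2ccc(C(F)(F)F)cc2)C1` and compound 3 `O=C1C=CCC(/C=C/c2ccc(C(F)(F)F)cc2)O1` are built from the same atoms joined differently; the difference between the two cores is not broken down here. In a functional assay on NCI/ADR cells (Homo sapiens) for inhibition, read by sulforhodamine B assay, with a stated time of 48 h (a higher number here means a weaker inhibitor of growth, a lower number a stronger inhibitor of growth), compound 1 gives 51.6 uM, and compound 3 gives 54.8 uM, a pair that lies within the usual scatter of such measurements. Compound 2 `COc1ccc(/C=C/C2CC(=O)C=CO2)cc1` differs from compound 1 by methoxy in place of trifluoromethyl on an aromatic carbon; in this assay compound 2 gives 239 uM, so that a 4.6-fold higher number from compound 1 to compound 2 (0.67 log units; beyond the scatter). Compound 4 `COc1ccc(/C=C/C2CC=CC(=O)O2)cc1` has not been measured. It stands to compound 3 as compound 2 stands to compound 1, through (methoxy in place of trifluoromethyl on an aromatic carbon), the same change at the same place, seen in both pairs among these compounds. Because compound 1 at 51.6 uM and compound 3 at 54.8 uM sit within the scatter of each other in this assay, the step from the trifluoromethyl to the methoxy partner is expected to repeat: a 4.4-fold higher number from compound 3 to compound 4 (0.64 log units; beyond the scatter), resting on a 4.6-fold higher number from compound 1 to compound 2 (0.67 log units; beyond the scatter). Compound 4 is therefore estimated at 240 uM in this assay, with a likely range from 100 uM to 600 uM.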

Compound 4, concentration for growth inhibition (reported as GI): 17.3 uM
Beside the measured number, compound 4's estimate is 14-fold (1.14 log units) above it, and the stated range ends above it.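

In this assay the move from trifluoromethyl to methoxy gives a 3.2-fold lower number from compound 3 to compound 4 (0.50 log units; beyond the scatter) and so runs the opposite way to a 4.6-fold higher number from compound 1 to compound 2 (0.67 log units; beyond the scatter) on the other core. The effect of this change therefore did not carry from the core of compound 1 to the core of compound 3, even though the two trifluoromethyl compounds read alike, and the size and direction seen on one core could not be used to predict the other: the same change on two cores in this assay, a 4.6-fold higher number (0.67 log units; beyond the scatter) from compound 1 to compound 2 and a 3.2-fold lower number (0.50 log units; beyond the scatter) from compound 3 to compound 4, 15-fold (1.17 log units) apart, beyond the scatter of two such steps. This shows only that the outcome of the change depends on the core in these two pairs; it does not show why the direction reverses, nor whether the reversal would hold in any other assay.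

The compounds shown leave open how other groups in the same place on the aromatic ring, such as a hydroxyl, a chlorine or an amine, would behave on each core. They also leave open whether any such group would follow the methoxy pattern or the trifluoromethyl pattern.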